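Notes on the change from compound 3 to compound 4

The source may report more compounds than this note shows. Statements on the series, on what has been measured and on what is new or still open speak of the compounds shown alone.

Measured so far, all in a functional assay on MCF7 cells (Homo sapiens) for cytotoxicity, read by sulforhodamine B assay, with a stated time of 3 days; a lower number here means a stronger inhibitor, a higher number a weaker inhibitor:
Compound 1, `O=c1cc[nH]c(=O)n1C1CN(S(=O)(=O)c2ccccc2[N+](=O)[O-])c2ccccc2CO1`, gives 50900 nM.
Compound 2, `O=[N+]([O-])c1ccccc1S(=O)(=O)N1CC(n2cnc3c(I)nc(Cl)nc32)OCc2ccccc21`, gives 610 nM.
Compound 3, `O=[N+]([O-])c1ccccc1S(=O)(=O)N1CC(n2cnc3nc(Cl)nc(Cl)c32)OCc2ccccc21`, gives 990 nM.

Compound 3 holds the second highest of the three numbers. Its nearest neighbour is compound 2: a 1.6-fold higher number from compound 2 to compound 3 (0.21 log units; within the scatter), which is within the scatter. The distance to compound 1 is large: a 51-fold lower number from compound 1 to compound 3 (1.71 log units; beyond the scatter). The same large drop is seen in an 83-fold lower number from compound 1 to compound 2 (1.92 log units; beyond the scatter), so the group of 11 heavy atoms on the saturated ring carbon, in place of the group of 8 heavy atoms, accounts for nearly all the spread among the three.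

Compound 4, `O=[N+]([O-])c1ccccc1S(=O)(=O)N1CC(n2cnc3c(Br)ncnc32)OCc2ccccc21`, is not yet measured. Within the data shown here, the change is a group of 10 heavy atoms (5 carbon, 4 nitrogen, 1 bromine; one five-membered aromatic ring with 2 hetero atoms, one six-membered aromatic ring with 2 hetero atoms) in place of a group of 11 heavy atoms (5 carbon, 4 nitrogen, 2 chlorine; one five-membered aromatic ring with 2 hetero atoms, one six-membered aromatic ring with 2 hetero atoms), on a saturated ring carbon; the place is the same saturated ring carbon that carried the change in the earlier steps. The step that bears on this is a 1.6-fold higher number from compound 2 to compound 3 (0.21 log units; within the scatter), a halogen exchange within the same bicyclic group that stayed within the scatter. Compound 4 exchanges one halogen and loses the other, a somewhat larger change than that, but nothing measured points to a shift beyond the scatter. No step beyond the scatter is expected: a 1.1-fold lower number from compound 3 to compound 4 (0.04 log units; within the scatter). Compound 4 is therefore estimated at 900 nM, in the range 300 nM to 3000 nM.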

Compound 4, half-maximal inhibitory concentration: 3620 nM
Estimate against measurement, compound 4: 4.0-fold (0.60 log units) below, and the stated range ends below it.
By their numbers in this assay, from the lowest: compounds 2 and 3 (each within the scatter of the next); then compound 4; then compound 1.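

In this assay, exchanges among groups with the same two aromatic rings on the saturated ring carbon, next to the ring oxygen, can move the number beyond the scatter: this holds for a 3.7-fold higher number from compound 3 to compound 4 (0.56 log units; beyond the scatter) and for a 5.9-fold higher number from compound 2 to compound 4 (0.77 log units; beyond the scatter), whereas the earlier exchange between the two groups carrying two halogens stayed within it. The group of 10 heavy atoms with 1 bromine still stands well clear of the group of 8 heavy atoms with its single six-membered aromatic ring (a 14-fold lower number from compound 1 to compound 4 (1.15 log units; beyond the scatter)), so among these four compounds all three groups with two aromatic rings give lower numbers than compound 1, and none goes against this, though the size of that gap depends on the halogens carried. Nothing measured speaks to the reason for the higher number of compound 4.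

Compound 4 differs from compound 2 and from compound 3 in more than one halogen, so these compounds cannot separate the effect of having bromine from that of carrying one halogen instead of two. Also open, from the compounds shown here alone, is whether an amine or a methoxy group in place of a halogen on this group would keep the number near that of compound 3 or move it towards that of compound 1.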